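Thiophen-3-yl in place of phenyl: working notes

The source may report more compounds than this note shows. Statements on the series, on what has been measured and on what is new or still open speak of the compounds shown alone.

Measured in a functional assay on A549 cells (Homo sapiens) for cytotoxicity; a higher number here means a weaker inhibitor, a lower number a stronger inhibitor:
- compound 1 `C=C/C=C\[C@H](C)[C@H](OC(N)=O)[C@@H](C)[C@H](O)[C@@H](C)C/C(C)=C\[C@H](C)[C@@H](O)[C@@H](C)/C=C\CCc1ccc(C)c(F)c1`: 4000 nM
- compound 2 `C=C/C=C\[C@H](C)[C@H](OC(N)=O)[C@@H](C)[C@H](O)[C@@H](C)C/C(C)=C\[C@H](C)[C@@H](O)[C@@H](C)/C=C\CCc1ccc(C)c(O)c1`: 4000 nM
- compound 3 `C=C/C=C\[C@H](C)[C@H](OC(N)=O)[C@@H](C)[C@H](O)[C@@H](C)C/C(C)=C\[C@H](C)[C@@H](O)[C@@H](C)/C=C\CCc1ccccc1`: 510 nM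

Compound 3 has the lowest number of the three, at 510 nM. The next compound to consider is compound 4 `C=C/C=C\[C@H](C)[C@H](OC(N)=O)[C@@H](C)[C@H](O)[C@@H](C)C/C(C)=C\[C@H](C)[C@@H](O)[C@@H](C)/C=C\CCc1ccsc1`, and the change is thiophen-3-yl in place of phenyl on a saturated chain carbon, two bonds along the chain from a double-bonded chain carbon.

Among the compounds with values here, two measured steps concern this same group: a 7.8-fold lower number from compound 1 to compound 3 (0.89 log units; beyond the scatter) and a 7.8-fold lower number from compound 2 to compound 3 (0.89 log units; beyond the scatter). Both are modest. Between the two substituted compounds, the step is no change at the digits printed from compound 1 to compound 2 (within the scatter). Within the data shown here, no measured compound carries a five-membered aromatic ring, so these steps give no direct size for the new change. They bear on it only indirectly: compound 4, like compound 3 at 510 nM, has no added substituent on its aromatic ring. A return towards the higher numbers of compound 1 and compound 2 is therefore not expected. The expected change in this assay is a 1.2-fold higher number from compound 3 to compound 4 (0.08 log units; within the scatter), with no shift beyond the scatter anticipated. The estimated value for compound 4 is 620 nM, with an expected range of 220 nM to 1800 nM.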

Compound 4, half-maximal inhibitory concentration: 4000 nM
Compound 4: the middle estimate sits 6.5-fold (0.81 log units) below what was measured, outside the stated range (above it).
By their numbers in this assay, from the lowest: compound 3; then compounds 1, 2 and 4 (each within the scatter of the next).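

In this assay, a 7.8-fold higher number from compound 3 to compound 4 (0.89 log units; beyond the scatter) shows that the step away from phenyl at this saturated chain carbon does not need an added ring substituent: replacing the six-membered ring with thiophen-3-yl is enough. The new ring also does not separate from the two substituted phenyl compounds, with no change at the digits printed from compound 2 to compound 4 (within the scatter) and no change at the digits printed from compound 1 to compound 4 (within the scatter) so far, among the four compounds, only compound 3 stands apart. Nothing measured bears on the reason for this difference between phenyl and thiophen-3-yl.

Still open, as far as these compounds go, is whether a furan-3-yl, thiophen-2-yl or pyridin-3-yl ring at this place would fall with compound 3 or with compound 4. Also open, from the compounds shown here alone, is whether a single fluoro or methyl group on the phenyl ring, rather than the pairs in compound 1 and compound 2, would be enough to move the number from that of compound 3.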